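This account rests on a few compounds, and the source may have more. Where it says the series, first, only, none or still open, it means among the compounds named here.

Measured so far in a functional assay on the whole organism (strain albino) for inhibition, with Rattus norvegicus as the target, read by paw edema, with stated times of 1 h and 3 h, at a dose of 25 mg/kg by the oral route; on this read-out lower numbers stand for less inhibition and higher numbers for more inhibition at the one dose given (going by the name of the read-out):
- compound 1 `CC1=C(C(=O)Nc2ccc(F)cc2)C(c2ccc(Br)cc2)n2c(s/c(=C/c3ccccc3)c2=O)=N1` gives 5%
- compound 2 `CC1=C(C(=O)Nc2ccc(F)cc2)C(c2ccc(Br)cc2)n2c(s/c(=C/c3ccc(Cl)cc3)c2=O)=N1` gives 25%
- compound 3 `CC1=C(C(=O)Nc2ccc(F)cc2)C(c2ccc(Cl)cc2)n2c(s/c(=C/c3ccccc3Cl)c2=O)=N1` gives 16%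

Compound 2 carries the change chloro in place of hydrogen on an aromatic carbon relative to compound 1, and this step reads a number 20 percentage points higher from compound 1 to compound 2 (beyond the scatter). Compound 3 rests on a different core; the difference between the two cores is not broken down here. Compound 3 and compound 2 lie within the scatter of each other, while compound 3 stands beyond the scatter above compound 1.

Compound 4 `CC1=C(C(=O)Nc2ccc(F)cc2)C(c2ccc(Cl)cc2)n2c(s/c(=C/c3ccc(Cl)cc3Cl)c2=O)=N1` is not yet measured. It differs from compound 3 by chloro in place of hydrogen on an aromatic carbon, the same kind of change as from compound 1 to compound 2, though here the place is also meta to a chloro group, whereas in the earlier pair it is only para to a large group.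

Because the earlier step was a number 20 percentage points higher from compound 1 to compound 2 (beyond the scatter), a step of a number 12 percentage points higher from compound 3 to compound 4 (beyond the scatter) is expected, smaller since the two cores differ and compound 3 already sits higher than compound 1. Compound 4 is thus estimated at 28%, between 12% and 45%.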

Compound 4, a percentage reported as inhibition, in the whole organism at one dose (the size of the read-out at that dose, not a potency): 14%
Compound 4: middle estimate off by 14 percentage points, on the high side, and the stated range covers the measured number.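

In this assay, chloro in place of hydrogen on an aromatic carbon does not carry over from one core to the other as a fixed step: the same change on two cores in this assay, a number 20 percentage points higher (beyond the scatter) from compound 1 to compound 2 and a number 2 percentage points lower (within the scatter) from compound 3 to compound 4, 22 percentage points apart, beyond the scatter of two such steps. On the core of compound 3, 2-chlorophenyl to 2,4-dichlorophenyl reads a number 2 percentage points lower from compound 3 to compound 4 (within the scatter), so the two values cannot be told apart. This rests on a single pair on each core at one dose, and it does not show whether the gap follows from the difference between the cores or from the new chloro also being meta to a chloro group.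

Still open, as far as these compounds go, is whether a methoxy group, an amine or a carboxylic acid at this place would shift the read-out on either core.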